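This account rests on a few compounds, and the source may have more. Where it says the series, first, only, none or still open, it means among the compounds named here.

Measured so far in a functional assay on MKN-45 cells (Homo sapiens) for cytotoxicity, read by MTT assay, with a stated time of 72 h; on this read-out higher numbers stand for weaker inhibition and lower numbers for stronger inhibition:

compound 1, `COc1ccc(OC)c(/C=N/NC(=O)Nc2ccc(Oc3ccnc(-c4nncn4CCN(C)C)c3)c(F)c2)c1`, gives 1510 nM
compound 2, `CN(C)CCn1cnnc1-c1cc(Oc2ccc(NC(=O)N/N=C/c3cccc(Br)c3)cc2F)ccn1`, gives 450 nM
compound 3, `CN(C)CCn1cnnc1-c1cc(Oc2ccc(NC(=O)N/N=C/c3cccc(O)c3)cc2F)ccn1`, gives 1370 nM

Compound 3 stands second highest of the three numbers in this assay; its nearest neighbour is compound 1, and a 1.1-fold lower number from compound 1 to compound 3 (0.04 log units; within the scatter) lies within the scatter, so the two cannot be ranked against each other. The one clear gap is to compound 2: a 3.0-fold higher number from compound 2 to compound 3 (0.48 log units; beyond the scatter).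

Compound 4, `CN(C)CCn1cnnc1-c1cc(Oc2ccc(NC(=O)N/N=C/c3ccc(F)cc3Cl)cc2F)ccn1`, is not yet measured. It differs from compound 3 in one place: 2-chloro-4-fluorophenyl in place of 3-hydroxyphenyl on a carbon with a double bond to nitrogen.

Among the compounds with values here, two measured steps bear on this change. Both a 3.4-fold lower number from compound 1 to compound 2 (0.53 log units; beyond the scatter) and a 3.0-fold higher number from compound 2 to compound 3 (0.48 log units; beyond the scatter) concern the ring on the carbon with a double bond to nitrogen, and in both the bromo-bearing ring gave the lower number, while the hydroxy-bearing ring and the dimethoxy-bearing ring sat close together. Within the data shown here, no measured step carries a chlorine or a second halogen on that ring, so the step to compound 4 is read from the hydroxy-to-halogen direction only. The expectation is a modest fall in the number, of about a 2.3-fold lower number from compound 3 to compound 4 (0.36 log units; beyond the scatter), landing near the value of compound 2. Compound 4 is estimated at 600 nM, in the range 250 nM to 1500 nM.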

Compound 4, half-maximal inhibitory concentration: 870 nM
Estimate against measurement, compound 4: 1.5-fold (0.16 log units) below; measured number inside the range.
By their numbers in this assay, from the lowest: compounds 2, 4, 3 and 1 (each within the scatter of the next, the first and the last beyond it).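

In this assay, the 2-chloro-4-fluorophenyl ring on the carbon with a double bond to nitrogen cannot be separated from the 3-hydroxyphenyl ring (a 1.6-fold lower number from compound 3 to compound 4 (0.20 log units; within the scatter)), the 3-bromophenyl ring (a 1.9-fold higher number from compound 2 to compound 4 (0.29 log units; within the scatter)) or the 2,5-dimethoxyphenyl ring (a 1.7-fold lower number from compound 1 to compound 4 (0.24 log units; within the scatter)). The earlier compounds shown here fell into two sets at this position, compound 2 on one side and compounds 1 and 3 on the other, whereas compound 4 sits within the scatter of all three and so blurs that division into a continuous run. Carrying two halogens on this ring therefore does not reproduce the clear separation from compounds 1 and 3 seen with the single bromo of compound 2, so halogen on the ring does not by itself mark out a distinct set among these four compounds.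

The compounds shown leave open whether the gap around compound 2 belongs to bromo specifically, and how a ring bearing an amine or a carboxylic acid would compare. No measurement is available that would explain any of these numbers.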